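Adding a Quinolin-2-yl Group at the Methoxy Carbon

The compounds below may be only part of what the source reports. "The series", "measured", "known", "first", "only" and "open" are said of these compounds alone.

Three compounds have so far been measured in a functional assay for inhibition; a lower number here means a stronger inhibitor, a higher number a weaker inhibitor:

compound 1 `CCN(CC)C(=O)COc1ccc2c(=O)cc(-c3cc(C(C)(C)C)c(O)c(C(C)(C)C)c3)oc2c1` gives 3000 nM
compound 2 `CC(C)(C)c1cc(-c2cc(=O)c3ccc(O)cc3o2)cc(C(C)(C)C)c1O` gives 1000 nM
compound 3 `COc1ccc2c(=O)cc(-c3cc(C(C)(C)C)c(O)c(C(C)(C)C)c3)oc2c1` gives 1000 nM

Compound 3 stands level with compound 2 at the digits shown, and these two together give the lowest numbers of the three. Compound 1 is the furthest away: the step of a 3.0-fold lower number from compound 1 to compound 3 (0.48 log units; beyond the scatter) lies beyond the scatter, as does a 3.0-fold lower number from compound 1 to compound 2 (0.48 log units; beyond the scatter). The step of no change at the digits printed from compound 2 to compound 3 (within the scatter) shows that methyl in place of hydrogen on the oxygen makes no difference here.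

Compound 4 `CC(C)(C)c1cc(-c2cc(=O)c3ccc(OCc4ccc5ccccc5n4)cc3o2)cc(C(C)(C)C)c1O` is the next compound to be measured. Its change from compound 3 is quinolin-2-yl in place of hydrogen on a saturated chain carbon bound to an oxygen on an aromatic ring. The step from compound 1 to compound 3 touches the same place, since there a diethylcarbamoyl group was removed from that carbon and the number fell by a 3.0-fold lower number from compound 1 to compound 3 (0.48 log units; beyond the scatter). Putting a sizeable group back onto that carbon would therefore be expected to move the number the other way by a similar modest amount, although quinolin-2-yl is a different group and the direction is not certain. Compound 4 is thus expected to give about 2000 nM, in the range 700 nM to 6000 nM, which amounts to an expected step of a 2.0-fold higher number from compound 3 to compound 4 (0.30 log units; within the scatter).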

Compound 4, half-maximal inhibitory concentration: 3000 nM
The estimate for compound 4 lay 1.5-fold (0.18 log units) below the measured number; measured number inside the range.
By their numbers in this assay, from the lowest: compounds 2 and 3 (each within the scatter of the next); then compounds 1 and 4 (each within the scatter of the next).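

In this assay, placing quinolin-2-yl on the saturated chain carbon bound to the oxygen gives a 3.0-fold higher number from compound 3 to compound 4 (0.48 log units; beyond the scatter), and the same comparison made against the free hydroxyl compound, where (quinolin-2-yl)methyl replaces hydrogen on the oxygen, gives a 3.0-fold higher number from compound 2 to compound 4 (0.48 log units; beyond the scatter). For the compounds shown here, until now, compound 1 was the only example with a larger group at this position, so its higher number could have been peculiar to diethylcarbamoyl, but replacing that group with quinolin-2-yl gives no change at the digits printed from compound 1 to compound 4 (within the scatter); across these four compounds, the two with a larger group here share the higher number, and none goes against this. No available evidence bears on what lies behind this shared shift.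

These compounds leave open whether the higher number follows from size alone or whether a different kind of group at this carbon, such as an amine or a carboxylic acid, would behave differently. A plain phenyl in place of quinolin-2-yl would test whether the ring nitrogen matters, while a longer chain between the oxygen and the quinolin-2-yl group would show whether its distance from the core changes the number.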